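The source may report more compounds than this note shows. Statements on the series, on what has been measured and on what is new or still open speak of the compounds shown alone.

Compound 1, `CCCCNc1nc(N)nc2c1CN(Cc1ccccc1)CC2`, is the reference point here. In an assay on HEK293 cells for agonist activity at Toll-like receptor 8 (Homo sapiens), read by a luciferase reporter, with a stated time of 6 h (on this read-out higher numbers stand for an effect only at larger amounts of compound and lower numbers for an effect already at smaller amounts), compound 1 gives 0.06 uM, the lowest of the two numbers obtained so far. Among the compounds with values here, its only measured companion is compound 2, `CCCCNc1nc(N)nc2c1CN(Cc1ccc(OC(F)(F)F)cc1)CC2`, which carries a trifluoromethoxy in place of hydrogen on an aromatic carbon and in this assay gives 0.24 uM; the change works out as a 4.0-fold higher number from compound 1 to compound 2 (0.60 log units; beyond the scatter), so adding a group to the aromatic ring at the end of the side chain made the compound active only at larger amounts.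

Compound 3, `CCCCNc1nc(N)nc2c1CN(Cc1ccccn1)CC2`, is not yet measured. Compared with compound 1 it shows (pyridin-2-yl in place of phenyl on a saturated chain carbon bound to an amine nitrogen in a ring). Within the data shown here, this is a different kind of change from the one seen between compound 1 and compound 2: nothing is added to the ring, rather one ring carbon becomes a nitrogen. Among the measured compounds shown here, the single measured step therefore bears on it only loosely, as a hint that alterations to this ring tend to cost rather than gain. A small step toward higher numbers, possibly within the scatter, is expected. For compound 3 the estimated value in this assay is 0.12 uM, with a range from 0.04 uM to 0.4 uM, which means an expected step of a 2.0-fold higher number from compound 1 to compound 3 (0.30 log units; within the scatter).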

Compound 3, minimum effective concentration: 0.07 uM
For compound 3 the middle estimate is 1.7-fold (0.23 log units) above the measured one, and the stated range covers the measured number.
By their numbers in this assay, from the lowest: compounds 1 and 3 (each within the scatter of the next); then compound 2.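

In this assay, putting pyridin-2-yl in place of phenyl on a saturated chain carbon bound to an amine nitrogen in a ring gives a 1.2-fold higher number from compound 1 to compound 3 (0.07 log units; within the scatter), so the numbers for compound 1 and compound 3 cannot be told apart. This shows something that the earlier pair could not: the ring at the end of the side chain can take a nitrogen in place of a carbon, and with it a hydrogen-bond acceptor, without a step beyond the scatter, whereas adding trifluoromethoxy gave a 4.0-fold higher number from compound 1 to compound 2 (0.60 log units; beyond the scatter). Not every alteration of this ring therefore moves the number, although nothing measured here accounts for the difference between these two changes.

On these data alone, it remains open whether the step seen with trifluoromethoxy belongs to that group alone or would also appear with a smaller substituent on the ring, such as a methyl or a chlorine. Also unsettled is how far this position can stray from an aromatic ring, for example with cyclohexyl in place of phenyl, or with an amine or a carboxylic acid attached to the ring.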